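This account rests on a few compounds, and the source may have more. Where it says the series, first, only, none or still open, it means among the compounds named here.

Compound 1 `C/C(=N\NC(N)=O)c1ccc2[nH]c(-c3ccoc3)nc2c1` opens the series. In an ADME assay on Vero cells (Chlorocebus sabaeus) for cytotoxicity, read by MTT assay, with a stated time of 96 h (on this read-out lower numbers stand for higher toxicity in this test and higher numbers for lower toxicity in this test), compound 1 reaches only a limit of the test, > 100000 nM. Compound 2 `C/C(=N\NC(N)=O)c1ccc2[nH]c(C3CCCCC3)nc2c1` differs from it by cyclohexyl in place of furan-3-yl on an aromatic carbon. In this assay compound 2 likewise stops at a limit, > 100000 nM. The step that the two limits leave unreadable from compound 1 to compound 2 cannot be sized because of the limit of > 100000 nM in this assay, at which 2 of the 3 values shown sit. Within the data shown here, compound 3 `C/C(=N\NC(N)=S)c1ccc2[nH]c(-c3ccoc3)nc2c1` differs from compound 1 by a group of 3 heavy atoms (1 carbon, 1 nitrogen, 1 sulfur; no ring) in place of a group of 3 heavy atoms (1 carbon, 1 nitrogen, 1 oxygen; no ring), on an amine nitrogen, and in this assay compound 3 gives 100000 nM, the only plain number of the three, so the step of a number no higher from compound 1 to compound 3 (the limit leaves the size open) is read from one side only. Compound 4 `C/C(=N\NC(N)=S)c1ccc2[nH]c(C3CCCCC3)nc2c1` is not yet measured; it differs from compound 3 by cyclohexyl in place of furan-3-yl on an aromatic carbon, the same change as that between compound 1 and compound 2. Compound 3 gives 100000 nM, and the earlier step that the two limits leave unreadable from compound 1 to compound 2 gave no readable size. On that basis compound 4 is expected to show a step of about no change at the digits printed from compound 3 to compound 4 (within the scatter) and an estimated value in this assay of 100000 nM.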

Compound 4, half-maximal cytotoxic concentration: > 100000 nM
Compound 4 gave a limit, no number; the forecaster's own chance of this, stated with the estimate: 60%; the middle value lies on the limit itself.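

In this assay, cyclohexyl in place of furan-3-yl on the core carrying the sulfur group gives a number no lower from compound 3 to compound 4 (the limit leaves the size open). Compound 4 gives only a limit of the test, > 100000 nM, and not a number. The change thus shows no fall in the number on this core, but its size cannot be read or compared with that on the core carrying the oxygen group, and the steps between two limits cannot be read either, because most values stop at the same limit: the limit of > 100000 nM in this assay, at which 3 of the 4 values shown sit.

The compounds shown leave open whether another group at this place, such as an amine, a carboxylic acid or a longer alkyl chain, would give a readable number in this assay. They also leave open where compound 1, compound 2 and compound 4 truly lie beyond the limit of the test.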